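This account rests on a few compounds, and the source may have more. Where it says the series, first, only, none or still open, it means among the compounds named here.

Compound 3 `COc1ccc(/C=C/C2CC=CC(=O)N2)cc1OC` gives only a limit in a functional assay on OVCAR-3 cells (Homo sapiens) for inhibition, read by sulforhodamine B assay, with a stated time of 48 h; a higher number here means a weaker inhibitor of growth, a lower number a stronger inhibitor of growth: compound 3 reports > 964 uM. Compound 2 `COc1ccc(/C=C/C2CC=CC(=O)N2)c(OC)c1` likewise returns a limit, > 964 uM, in this assay. Both sit at the limit of > 964 uM in this assay, at which 2 of the 3 values shown sit, so compound 3 stands with compound 2 at the edge of what this assay can report, and no order between the two can be read. For the measured compounds named here, compound 1 `COc1cc(OC)c(OC)cc1/C=C/C1CC=CC(=O)O1`, on a different core, gives 7.2 uM in this assay, the one numerical value in the set. Compound 4 `COc1cc(OC)c(OC)cc1/C=C/C1CC=CC(=O)N1` is yet to be measured in this assay.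

From compound 3 to compound 4 the change is methoxy in place of hydrogen on an aromatic carbon. The resulting methoxy pattern matches that of compound 1, while the core of compound 3 is kept. Going by the values given here, no measured pair differs in one place, so the size of this step cannot be computed from the data. Because compound 3 gives > 964 uM, the expectation for compound 4 leans toward another limit rather than a numerical value. Compound 4 is expected near 500 uM, within 40 uM to 2000 uM. That estimate means an expected step of an at least 1.9-fold lower number from compound 3 to compound 4 (0.28 log units; that floor lies within the scatter), not beyond the scatter.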

Compound 4, concentration for growth inhibition (reported as GI): > 864 uM
Compound 4 ended at the assay's limit; the forecaster's own chance of this, stated with the estimate: 65%; middle value at least 1.7-fold (0.23 log units) away from the limit.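

Compound 4 gives only a limit in this assay: the limit of > 864 uM in this assay, at which 1 of the 4 values shown sits. The steps to compound 4 from compound 3 and from compound 2 cannot be read, both ends being limits, so the effect of methoxy in place of hydrogen on this aromatic carbon stays unsized. For the compounds shown here, the new information is a first readable pair that shares the methoxy pattern and differs only in the group on the double-bonded chain carbon, and that swap gives an at least 120-fold higher number from compound 1 to compound 4 (2.07 log units; beyond the scatter).

Open, on these data alone, is whether a group other than methoxy on this aromatic carbon, such as hydroxyl or fluorine, would give a numerical value on the core of compound 4. Also open, as far as these compounds go, is whether a methyl in place of the amide hydrogen would do so.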